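The compounds below may be only part of what the source reports. "The series", "measured", "known", "first", "only" and "open" are said of these compounds alone.

Measured compounds:
compound 1, `Cc1cc(F)c(S(C)(=O)=O)cc1C(=O)N=C(N)N`, 44 nM
compound 2, `Cc1c(C(=O)N=C(N)N)cc(S(C)(=O)=O)c(C)c1C`, 55 nM
compound 3, `Cc1ccc(-c2ccc(C(=O)N=C(N)N)cc2S(C)(=O)=O)cc1`, 100 nM

In a functional assay for inhibition of sodium/hydrogen exchanger (Oryctolagus cuniculus) (on this read-out lower numbers stand for stronger inhibition and higher numbers for weaker inhibition), compound 1 shows the lowest of the three numbers. The number of compound 2 lies within the scatter of it, so no order is read between compound 1 and compound 2. Compound 3 gives a higher number than compound 1, and that gap lies beyond the scatter. Compound 4, `Cc1cc(-c2cc(Cl)cc(Cl)c2)c(S(C)(=O)=O)cc1C(=O)N=C(N)N`, is not yet measured. The change from compound 1 to compound 4 is 3,5-dichlorophenyl in place of fluoro on an aromatic carbon. Among the measured compounds shown here, no single-point step between measured compounds is available for comparison. Compound 3, whose structure also bears a six-membered aromatic ring of carbon only on the shared core, gives 100 nM, a higher number than compound 1. On that basis a modest step toward higher numbers is expected for compound 4, a 2.3-fold higher number from compound 1 to compound 4 (0.36 log units; beyond the scatter), near the edge of the scatter. Compound 4 is estimated at 100 nM, with a range from 35 nM to 300 nM.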

Compound 4, half-maximal inhibitory concentration: 130 nM
Compound 4: the middle estimate sits 1.3-fold (0.11 log units) below what was measured; measured number inside the range.
By their numbers in this assay, from the lowest: compounds 1, 2, 3 and 4 (each within the scatter of the next, the first and the last beyond it).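

In this assay the position ortho to the methylsulfonyl group accepts 3,5-dichlorophenyl in place of fluoro, with a 3.0-fold higher number from compound 1 to compound 4 (0.47 log units; beyond the scatter) as a modest cost. A far larger group with an added aromatic ring therefore does not abolish inhibition at this aromatic carbon, and compound 4 still gives 130 nM. No measured data explain the size of this step.

Going by these compounds, whether the step follows from the added ring or from its two chlorines remains open. Also open, on these data alone, is how an unsubstituted phenyl, a methoxy group or an amine would read at this position.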